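A few compounds are considered here, and "the series" means these few. Any claim that something is new, unique, unknown or untested is made for them only; others in the source may bear on it.

Measured so far:
- compound 1, `CCOc1ccccc1NC(=O)CSc1c[nH]c2c(Cl)cccc12`: in an ADME assay on HEK-293T cells (Homo sapiens) for cytotoxicity, read by CCK-8 assay, with a stated time of 48 h (a lower number here means that less compound is tolerated, a higher number that more compound is tolerated), compound 1 gives > 100000 nM, which is a limit of the assay and not a number.
- compound 2, `Cn1cc(SCC(=O)Nc2c(Cl)cccc2Cl)c2ccccc21`: in this assay compound 2 gives > 100000 nM, again a limit.
- compound 3, `Cn1cc(S(=O)(=O)CC(=O)Nc2cc(Cl)ccc2Cl)c2ccccc21`: in this assay compound 3 gives > 100000 nM, also a limit.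

Compound 3 therefore stands only at the limit; no number places it against the others. The same holds across the whole set, as the limit of > 100000 nM in this assay, at which 3 of the 3 values shown sit, shows. For the measured compounds named here, no step between two measured compounds can be drawn, since none of the three differs from another in a single place.

Compound 4, `Cn1cc(S(=O)(=O)CC(=O)Nc2cccc(Cl)c2Cl)c2ccccc21`, is next. Relative to compound 3 the change is 2,3-dichlorophenyl in place of 2,5-dichlorophenyl on an amide-type nitrogen, the two having the same atoms joined differently. Nothing measured bears on this rearrangement. Given that every value so far sits at the limit, the expectation in this assay is for no step beyond the scatter from compound 3 to compound 4, and most probably another limit. Compound 4 is expected to give 150000 nM, with a range from 60000 nM to 400000 nM. The step this implies, a step that the limit leaves unreadable from compound 3 to compound 4, is expected to lie within the scatter.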

Compound 4, half-maximal cytotoxic concentration: > 100000 nM
Compound 4 was reported as a limit (the forecaster's own chance of this, stated with the estimate: 80%); the middle value does not contradict the limit.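

No step can be read from compound 3 to compound 4, as both results are limits and not numbers: the limit of > 100000 nM in this assay, at which 4 of the 4 values shown sit.

The compounds shown leave open how much of any of them is tolerated in this assay, and whether 2,3-dichlorophenyl in place of 2,5-dichlorophenyl on an amide-type nitrogen changes that at all.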